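The source may hold more compounds than are shown below. What is called first, only, known or untested is meant among the compounds shown, and "the series" means these compounds.

Of the compounds shown here, two have been measured in an ADME assay on microsomes from liver (Homo sapiens) for metabolic stability, with a stated time of 0.5 h, tested at 0.5 mg/mL; on this read-out lower numbers stand for a less stable compound and higher numbers for a more stable compound. Compound 1, `CC(C)C(=O)N1CC2(CC(NC(=O)c3cc(-c4ccccc4)no3)C2)C1`, is the less stable of the pair: in this assay compound 1 gives 79%. Compound 2, `CC(CC(=O)N(C)C)NC(=O)c1cc(-c2ccc(F)cc2)no1`, gives 91% in this assay, a number that sits higher than that of compound 1 by more than the usual scatter of such measurements. The two structures differ in several places at once, so nothing can be said about which of those differences matters.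

Compound 3, `CCN1CC2(CC(NC(=O)c3cc(-c4ccccc4)no3)C2)C1`, is built from compound 1 by a single change: ethyl in place of isopropylcarbonyl on an amine nitrogen in a ring. The group that leaves is an isopropylcarbonyl with one hydrogen-bond acceptor; the ethyl that enters brings none. Among the compounds with values here, no measured pair shows a comparable change, so the size of the effect is unknown. The step of a number 24 percentage points lower from compound 1 to compound 3 (beyond the scatter) is expected to run downward, beyond the scatter. For compound 3 the expected value in this assay is 55%, within a range from 30% to 80%.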

Compound 3, percent of the compound remaining: 100%
For compound 3 the middle estimate is 45 percentage points below the measured one; the measured number lies above the stated range.
By their numbers in this assay, from the lowest: compound 1; then compounds 2 and 3 (each within the scatter of the next).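

Putting ethyl in place of isopropylcarbonyl on the amine nitrogen in the ring gives, in this assay, a number 21 percentage points higher from compound 1 to compound 3 (beyond the scatter), so what sits on this nitrogen does affect the read-out, and the isopropylcarbonyl can leave without any loss of stability. The ethyl is the smaller group and brings no hydrogen-bond acceptor, but one step cannot show which of these differences matters. Nothing measured here accounts for the rise.

Going by these compounds, it stays open whether the gain comes from losing the carbonyl or from the size of the group, which a methyl, a longer alkyl chain or a smaller acyl group such as acetyl on this nitrogen could help to separate. On these data alone, it is also open whether the same swap would have a similar effect on another core.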